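The compounds below may be only part of what the source reports. "The series", "measured", "known", "first", "only" and "open" are said of these compounds alone.

Compound 1, `OC[C@H]1OC(n2cnc3c(-c4ccc(Cl)cc4)ncnc32)[C@H](O)[C@@H]1O`, gives 900 nM in a functional assay on CCRF-CEM cells (Homo sapiens) for inhibition; a lower number here means a stronger inhibitor, a higher number a weaker inhibitor.
Compound 2, `OC[C@H]1OC(n2cnc3c(-c4cc[nH]n4)ncnc32)[C@H](O)[C@@H]1O`, gives 750 nM in this assay.

For the measured compounds named here, compound 2 holds the lowest of the two numbers measured so far, but its nearest neighbour is compound 1, and the gap between them lies within the scatter, so the two cannot be ranked against each other. Going by the values given here, the single step measured so far, a 1.2-fold lower number from compound 1 to compound 2 (0.08 log units; within the scatter), shows that swapping the 4-chlorophenyl group for a 1H-pyrazol-3-yl group leaves the number essentially unchanged.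

Compound 3, `OC[C@H]1OC(n2cnc3c(-c4ccsc4)ncnc32)[C@H](O)[C@@H]1O`, has not yet been measured. It differs from compound 2 by thiophen-3-yl in place of 1H-pyrazol-3-yl on an aromatic carbon. The step that bears on this change is the one just described, which was within the scatter; one ring of similar size took the place of another without a shift in the number. On that basis the step from compound 2 to compound 3 is expected to be small, a 1.1-fold higher number from compound 2 to compound 3 (0.05 log units; within the scatter), with no clear direction beyond the scatter. Compound 3 is therefore estimated at 850 nM in this assay, within a range of 300 nM to 2500 nM.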

Compound 3, half-maximal inhibitory concentration: 1640 nM
Compound 3: middle estimate off by 1.9-fold (0.29 log units), on the low side; measured number inside the range.
By their numbers in this assay, from the lowest: compounds 2, 1 and 3 (each within the scatter of the next, the first and the last beyond it).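

In this assay, for the compounds shown here, the group on this aromatic carbon is not entirely interchangeable: a 2.2-fold higher number from compound 2 to compound 3 (0.34 log units; beyond the scatter) is the first step to pass beyond the scatter, although it is modest. It links two five-membered aromatic rings with the same heavy-atom count, of which the 1H-pyrazol-3-yl group has 1 hydrogen-bond donor and 2 ring hetero atoms, while the thiophen-3-yl group has 0 donors and a single sulfur as its hetero atom. The change shows only against compound 2, since a 1.8-fold higher number from compound 1 to compound 3 (0.26 log units; within the scatter) stays within the scatter, and no information is available to account for the difference between the two rings.

With a single pair, the compounds shown cannot tell whether the hydrogen-bond donor, the ring nitrogens or the sulfur lies behind the step, and a furan-3-yl or an N-methylpyrazolyl ring at the same place would be needed to separate these. They also leave open how this position responds to groups outside the aromatic rings, such as an amine or a short alkyl chain.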